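This account rests on a few compounds, and the source may have more. Where it says the series, first, only, none or still open, it means among the compounds named here.

Measured so far:
compound 1 `COc1cc(F)ccc1-c1cccc(Cn2ccc3ccc(NC(=O)C(C)(C)C)cc32)c1` — < 1000 ug/mL
compound 2 `COc1cc(F)ccc1-c1cccc(Cn2ccc3ccc(NC(=O)CC(C)(C)O)cc32)n1` — 17900 ug/mL
compound 3 `COc1cc(F)ccc1-c1cccc(Cc2cn(C)c3ccc(NC(=O)C(C)(C)CO)cc23)n1` — 2000 ug/mL

In a physicochemical assay for solubility (on this read-out higher numbers stand for higher solubility and lower numbers for lower solubility), compound 3 gives 2000 ug/mL, the lowest of the two numbers in hand; compound 2 gives 17900 ug/mL, a higher figure that lies beyond the scatter. For compound 1 only a limit is reported, < 1000 ug/mL (the limit of < 1000 ug/mL in this assay, at which 1 of the 3 values shown sits), not a number.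

Compound 4 `COc1cc(F)ccc1-c1cccc(Cc2cn(C)c3ccc(NC(=O)CC(C)(C)O)cc23)n1` has not yet been measured in this assay. It differs from compound 3 in one place: 2-hydroxy-2-methylpropyl in place of 1-(hydroxymethyl)-1-methylethyl on a carbonyl carbon. No measured pair in the series carries this change on its own, so its size cannot be read from a shown step. Compound 2 bears the same 2-hydroxy-2-methylpropyl group on its carbonyl and gives 17900 ug/mL, but its core is not that of compound 3 and compound 4, so the two values can only be set side by side.

The estimated step of a 3.0-fold higher number from compound 3 to compound 4 (0.48 log units; beyond the scatter) is expected upward, beyond the scatter. Compound 4 is expected at 6000 ug/mL, within 2000 ug/mL to 18000 ug/mL.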

Compound 4, solubility: 10600 ug/mL
Compound 4: middle estimate off by 1.8-fold (0.25 log units), on the low side; the range from low to high includes it.
By their numbers in this assay, from the lowest: compound 3; then compounds 4 and 2 (each within the scatter of the next). At a limit, below all of these: compound 1.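

In this assay the series now has its first step that changes one place only: 2-hydroxy-2-methylpropyl in place of 1-(hydroxymethyl)-1-methylethyl on a carbonyl carbon gives a 5.3-fold higher number from compound 3 to compound 4 (0.72 log units; beyond the scatter) and counts as modest. The two groups have the same atoms, joined differently, and the same counts of heavy atoms, donors and acceptors, yet the number moves beyond the scatter. At this position, then, the arrangement of the chain alone is enough to shift the read-out on the core of compound 3 and compound 4.

From the compounds shown here alone, whether the step carries over to the core of compound 2 stays open, as does the outcome with a longer chain, an amine or a carboxylic acid on this carbonyl carbon. Nothing given here offers a measured property that accounts for the step.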